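Swapping the chain-end acid for an alcohol

The source may report more compounds than this note shows. Statements on the series, on what has been measured and on what is new or still open speak of the compounds shown alone.

Compound 1, `c1ccc2cc(-c3noc(C4CCNCC4)n3)ccc2c1`, gives 580 nM in an assay on HepG2 cells for antagonist activity at Bile acid receptor (Homo sapiens), read by a luciferase reporter; a higher number here means a weaker inhibitor, a lower number a stronger inhibitor.
Compound 2, `OCCCN1CCC(c2nc(-c3ccc4ccccc4c3)no2)CC1`, gives 40400 nM in this assay.
Compound 3, `O=C(O)CCCN1CCC(c2nc(-c3ccc4ccccc4c3)no2)CC1`, gives 25700 nM in this assay.

Compound 3 stands second highest of the three numbers, close to compound 2 and far from compound 1: a 44-fold higher number from compound 1 to compound 3 (1.65 log units; beyond the scatter), while a 1.6-fold lower number from compound 2 to compound 3 (0.20 log units; within the scatter). Compound 4, `OCCCCN1CCC(c2nc(-c3ccc4ccccc4c3)no2)CC1`, differs from compound 3 by hydroxymethyl in place of carboxy on a saturated chain carbon, three bonds along the chain from an amine nitrogen in a ring. For the measured compounds named here, two measured steps bear on this. Adding either chain to the ring amine cost a great deal: a 70-fold higher number from compound 1 to compound 2 (1.84 log units; beyond the scatter) and a 44-fold higher number from compound 1 to compound 3 (1.65 log units; beyond the scatter). Yet exchanging the chain-end hydroxy for carboxy changed little: a 1.6-fold lower number from compound 2 to compound 3 (0.20 log units; within the scatter). Compound 4 keeps a hydroxy-ended chain, so no step beyond the scatter is expected: a 1.4-fold higher number from compound 3 to compound 4 (0.13 log units; within the scatter). Compound 4 is estimated at 35000 nM in this assay, with a range from 12000 nM to 100000 nM.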

Compound 4, half-maximal inhibitory concentration: 1170 nM
Estimate against measurement, compound 4: 30-fold (1.48 log units) above; measured number outside the range, below it.
By their numbers in this assay, from the lowest: compounds 1 and 4 (each within the scatter of the next); then compounds 3 and 2 (each within the scatter of the next).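

Neither the hydroxy end nor the ring-amine substitution decides the result alone; the chain matters as a whole. Going from 3-hydroxypropyl to 4-hydroxybutyl gives a 35-fold lower number from compound 2 to compound 4 (1.54 log units; beyond the scatter), and going from 3-carboxypropyl to 4-hydroxybutyl gives a 22-fold lower number from compound 3 to compound 4 (1.34 log units; beyond the scatter). A chain on the ring amine therefore need not cost activity in this assay: 4-hydroxybutyl in place of hydrogen gives a 2.0-fold higher number from compound 1 to compound 4 (0.30 log units; within the scatter). Nothing available here accounts for this sharp dependence on the chain. Still open, from the compounds shown here alone, is how a longer chain with a hydroxy end would read out, and whether a four-carbon-spaced chain such as 4-carboxybutyl, ending in a carboxylic acid, or one ending in an amine would match 4-hydroxybutyl.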